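Swapping Chloro for Methyl: Expectations for Compound 3

The compounds below may be only part of what the source reports. "The series", "measured", "known", "first", "only" and "open" are said of these compounds alone.

Two compounds from this series have so far been examined in a functional assay on A549 cells (Homo sapiens) for cytotoxicity, read by MTT assay, with a stated time of 4 days; a higher number here means a weaker inhibitor, a lower number a stronger inhibitor. Compound 1 `C=C1C[C@]23C[C@@]1(O)CC[C@H]2c1ccc(OS(=O)(=O)c2ccc(C)cc2)c(C)c1[C@@H]3Cn1cc(-c2ccc(OC)cc2)nn1` gives > 20000 nM, which is a limit of the assay and not a number. Compound 2 `C=C1C[C@]23C[C@@]1(O)CC[C@@H]2c1cccc(C)c1[C@@H]3Cn1cc(-c2ccc(Cl)cc2)nn1`, built on the same core, likewise gives > 20000 nM, again a limit rather than a measured figure. Compound 2 therefore stands at the limit of > 20000 nM in this assay, at which 2 of the 2 values shown sit, and nothing in the data places it anywhere more precise than that.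

Going by the values given here, no two measured compounds differ in a single place, so no measured step exists from which the effect of a small change could be read. Compound 3 `C=C1C[C@]23C[C@@]1(O)CC[C@@H]2c1cccc(C)c1[C@@H]3Cn1cc(-c2ccc(C)cc2)nn1` has not yet been tested. It differs from compound 2 by methyl in place of chloro on an aromatic carbon, the same difference, cut one bond further out, reading 4-chlorophenyl to 4-methylphenyl. With compound 2 sitting at a limit, the account can only expect the step that the limit leaves unreadable from compound 2 to compound 3 to lie within the usual scatter, with no direction favoured. Compound 3 is accordingly estimated at 25000 nM, within 10000 nM to 100000 nM, and most probably the assay would again report only a limit.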

Compound 3, half-maximal inhibitory concentration: > 20000 nM
Compound 3: a limit, no number (the forecaster's own chance of this, stated with the estimate: 85%); the middle value lies beyond the limit too.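

In this assay compound 3 gives > 20000 nM, which is a limit of the assay and not a number. Compound 2 also stands at a limit, so no step can be read between compound 2 and compound 3, and the position is this: the limit of > 20000 nM in this assay, at which 3 of the 3 values shown sit. The compounds shown leave open what any of them would give as an actual number, and whether methyl and chloro differ at all in this place.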